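A few compounds are considered here, and "the series" means these few. Any claim that something is new, unique, unknown or untested is made for them only; others in the source may bear on it.

In a functional assay on A549 cells (Homo sapiens) for inhibition, read by CCK-8 assay, with a stated time of 48 h (a lower number here means a stronger inhibitor, a higher number a weaker inhibitor), compound 1 `COc1cc(-c2cc3nccc(-c4cc(OC)c(OC)c(OC)c4)n3n2)cc(OC)c1OC` gives > 10000 nM, which is a limit of the assay and not a number. Compound 3 `COc1cc(-c2ccnc3cc(-c4cccc(C#N)c4)nn23)cc(OC)c1OC` gives > 10000 nM, which is likewise a limit. On these data alone, compound 3 therefore has no exact potency, and its true value remains unknown. The data so far are thin: the limit of > 10000 nM in this assay, at which 2 of the 3 values shown sit. Only compound 2 `Cn1ccc2cc(-c3cc4nccc(-c5ccc(F)cc5)n4n3)ccc21` gives a number, 3520 nM.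

Compound 4 `COc1cc(-c2ccnc3cc(-c4cn(C)c5ccccc45)nn23)cc(OC)c1OC` differs from compound 3 in one place, with 1-methyl-1H-indol-3-yl in place of 3-cyanophenyl on an aromatic carbon. For the measured compounds named here, no measured pair here isolates a single change, so the size of this step cannot be read directly from the data. The closest guide is compound 2 at 3520 nM, which also contains a 1-methyl-1H-indole unit, though it differs from compound 4 elsewhere and joins that unit differently. On that slender basis, a move towards stronger inhibition is expected, of uncertain size and possibly no larger than the scatter, and compound 4 could also remain at the limit. The expected change is an at least 4.0-fold lower number from compound 3 to compound 4 (0.60 log units; beyond the scatter). For compound 4, the estimated half-maximal inhibitory concentration is 2500 nM, within an expected range of 300 nM to 10000 nM.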

Compound 4, half-maximal inhibitory concentration: 1340 nM
The estimate for compound 4 lay 1.9-fold (0.27 log units) above the measured number; the range from low to high includes it.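

For the compounds shown here, this is the first measured pair that isolates a single change, and it shows that the group on an aromatic carbon of the five-membered aromatic ring with 2 nitrogen matters in this assay: 1-methyl-1H-indol-3-yl in place of 3-cyanophenyl gives an at least 7.4-fold lower number from compound 3 to compound 4 (0.87 log units; beyond the scatter). With the rest of the molecule unchanged, compound 4 gives 1340 nM, so a change at this place alone is enough to give a measurable potency. The step is only a minimum, since the value of compound 3 is a limit and not a number, and the true size of the change stays unknown: the limit of > 10000 nM in this assay, at which 2 of the 4 values shown sit.

Because the change swaps one whole group for another, it cannot separate the contribution of the five-membered ring in the indole from that of its methyl or of the way the group is attached. The compounds shown also leave open how an unsubstituted 1H-indol-3-yl, an amine, a carboxylic acid or a longer chain would behave at this place.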